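Swapping an ethoxy for an ethyl on a bisaziridinyl quinone side chain

This account rests on a few compounds, and the source may have more. Where it says the series, first, only, none or still open, it means among the compounds named here.

Measured so far:
compound 1, `CCCC1=C(N2CC2)C(=O)C(C(COC(N)=O)OC)=C(N2CC2)C1=O`, 5.01
compound 2, `CCOC(COC(N)=O)C1=C(N2CC2)C(=O)C(C)=C(N2CC2)C1=O`, 5.53

Of the compounds shown here, two have been tested in a functional assay on L1210 cells (Mus musculus), with a stated time of 1 days; on this read-out lower numbers stand for lower potency and higher numbers for higher potency (the scale is a negative logarithm). Compound 1 gives 5.01 and compound 2 gives 5.53; of the two numbers compound 2 holds the higher one, and its gap to compound 1 lies beyond the scatter. The two differ in more than one place, so no single change can be read from that gap.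

Compound 3, `CCC(COC(N)=O)C1=C(N2CC2)C(=O)C(C)=C(N2CC2)C1=O`, is the next candidate. It keeps the core of compound 2 and changes only the side chain: ethyl in place of ethoxy on a saturated chain carbon bound to a double-bonded ring carbon and a saturated chain carbon. Going by the values given here, no measured pair in this set isolates such a change, so there is no direct precedent for its effect in this assay. Given that, the expectation is that compound 3 will stay close to compound 2, with a step of a number 0.13 log units lower from compound 2 to compound 3 (within the scatter) that is expected to fall within the scatter or slightly below it. Compound 3 is therefore estimated at 5.4, with a range from 4.9 to 5.9.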

Compound 3, logarithm of the reciprocal of the active concentration, log(1/C): 6.03
Beside the measured number, compound 3's estimate is 0.63 log units below it; the whole stated range lies below it.
By their numbers in this assay, from the lowest: compound 1; then compound 2; then compound 3.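

Going by these compounds alone, compound 2 and compound 3 are the first pair here that differ in one place only, so a single change can now be read in this assay. The read-out shows a number 0.50 log units higher from compound 2 to compound 3 (beyond the scatter) for ethyl in place of ethoxy on a saturated chain carbon bound to a double-bonded ring carbon and a saturated chain carbon. This shows that the group at this position matters for the read-out, and that here the group without the oxygen goes with the higher potency.

Nothing measured here explains why the number moves in this direction.

On these data alone, this single pair cannot separate the loss of the oxygen from the loss of one chain atom, nor show how far the trend runs, so it is open how a hydroxyl, an amine or a longer chain such as butyl would behave on the same carbon. As far as these compounds go, it is also open whether the same swap would give a step of similar size with a different group on the rest of the shared core.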